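Chloro for Hydrogen on Two Related Cores in a Growth Assay

The source may report more compounds than this note shows. Statements on the series, on what has been measured and on what is new or still open speak of the compounds shown alone.

Measured in an ADME assay on MCF-10A cells (Homo sapiens) for cytotoxicity, read by sulforhodamine B assay, with a stated time of 48 h; a lower number here means a stronger inhibitor of growth, a higher number a weaker inhibitor of growth:
Compound 1 `CCN(CC)CN1C(=O)/C(=N\c2nc3ccc(C)cc3s2)c2ccccc21` gives 20400 nM
Compound 2 `CCN(CC)CN1C(=O)/C(=N\c2nc3ccc(C)cc3s2)c2c(Cl)cccc21` gives 43900 nM
Compound 3 `CN(C)CN1C(=O)C(=O)c2ccccc21` gives 150000 nM

Compound 1 and compound 2 share one core; compound 2 carries chloro in place of hydrogen on an aromatic carbon. That change produced a 2.2-fold higher number from compound 1 to compound 2 (0.33 log units; beyond the scatter), so the chloro compound inhibits growth less strongly. Compound 3 has a different core, and the difference between the two cores is not broken down here. Compound 3 gives the highest number of the three in this assay.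

Compound 4 `CN(C)CN1C(=O)C(=O)c2c(Cl)cccc21` has not been measured. It differs from compound 3 by chloro in place of hydrogen on an aromatic carbon, the same change as from compound 1 to compound 2, at the same place. The step from compound 3 to compound 4 is expected to be a 2.0-fold higher number from compound 3 to compound 4 (0.30 log units; within the scatter), because the earlier step was a 2.2-fold higher number from compound 1 to compound 2 (0.33 log units; beyond the scatter). Compound 4 is therefore estimated at 300000 nM, expected between 120000 nM and 700000 nM, with a fair chance that this assay reports only a limit.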

Compound 4, concentration for 50% growth inhibition: 82300 nM
Beside the measured number, compound 4's estimate is 3.6-fold (0.56 log units) above it; measured number outside the range, below it.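

In this assay, chloro in place of hydrogen on an aromatic carbon gives a 1.8-fold lower number from compound 3 to compound 4 (0.26 log units; within the scatter), so on this core the change makes no clear difference. Set beside the earlier step, the same change at the same place did not carry over from one core to the other: the same change on two cores in this assay, a 2.2-fold higher number (0.33 log units; beyond the scatter) from compound 1 to compound 2 and a 1.8-fold lower number (0.26 log units; within the scatter) from compound 3 to compound 4, 3.9-fold (0.59 log units) apart, beyond the scatter of two such steps. This shows that the step seen on one core is a poor guide to the other core in this series, but two pairs do not show what sets the cores apart or how the change would behave on a further core.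

The compounds shown leave open whether a different group in the same place, such as fluoro or methoxy, would also behave differently on the two cores. As far as these compounds go, the cores differ in more than one place, and which of those differences matters also remains open.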